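This account rests on a few compounds, and the source may have more. Where it says the series, first, only, none or still open, it means among the compounds named here.

Compound 3, `CC(C(=O)N1CCN(c2cccc(F)c2)CC1)N1C(=O)CCC1=O`, was tested in a functional assay on the whole organism (strain Swiss) with Mus musculus as the target, in the maximal electroshock model, with a stated time of 1 h, at a dose of 300 mg/kg by the intraperitoneal route (on this read-out higher numbers stand for a stronger effect at the one dose given and lower numbers for a weaker effect), and gave 75%. Its closest measured neighbour is compound 2, `CCC(C(=O)N1CCN(c2cccc(F)c2)CC1)N1C(=O)CCC1=O`, which in this assay gives 75%; the step of no change at the digits printed from compound 2 to compound 3 (within the scatter) leaves the two level. Compound 1, `COc1cccc(N2CCN(C(=O)C(C)N3C(=O)CCC3=O)CC2)c1`, is the distant member of the set, and in this assay compound 1 gives 0%; the step of a number 75 percentage points higher from compound 1 to compound 3 (beyond the scatter) is the only large move among the three. This step is a change at the aromatic ring.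

The new compound 4, `CC(C(=O)N1CCN(c2cccc(Cl)c2)CC1)N1C(=O)CCC1=O`, carries one change relative to compound 3: chloro in place of fluoro on an aromatic carbon. The step on the chain carbon, no change at the digits printed from compound 2 to compound 3 (within the scatter), does not touch this position and so says little about it. Among the measured compounds shown here, the one step at the aromatic carbon, a number 75 percentage points higher from compound 1 to compound 3 (beyond the scatter), shows that a swap there can move the read-out strongly, but it replaces a methoxy group, not one halogen for another. On this thin basis, compound 4 is expected to stay near compound 3, with a step of about no change at the digits printed from compound 3 to compound 4 (within the scatter) in this assay. The estimate for compound 4 in this assay is therefore 75%, ranging from 25% to 100%.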

Compound 4, a percentage reported as activity, at one dose (the size of the read-out at that dose, not a potency): 75%
The estimate for compound 4 equals the measured number at the digits printed; measured number inside the range.
By their numbers in this assay, from the lowest: compound 1; then compounds 2, 3 and 4 (each within the scatter of the next).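

In this assay the swap of one halogen for another at this aromatic carbon gives no change at the digits printed from compound 3 to compound 4 (within the scatter) on the shared core, so the 3-fluorophenyl and 3-chlorophenyl forms cannot be told apart at the one dose given. Chloro also matches the large gain that fluoro showed over methoxy, with a number 75 percentage points higher from compound 1 to compound 4 (beyond the scatter) at the same place, so that gain is no longer tied to fluoro alone. Nothing available explains why the two halogens stand level or why both part so sharply from methoxy.

From the compounds shown here alone, whether a bromo group or a nitrile at this carbon would hold the read-out, or an amine would bring it down to the level of methoxy, stays open. Going by these compounds, it also stays open whether the compounds level at this one dose would remain level at lower doses.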